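A few compounds are considered here, and "the series" means these few. Any claim that something is new, unique, unknown or untested is made for them only; others in the source may bear on it.

Measured so far in a functional assay on LM7 cells (Homo sapiens) for antiproliferative activity, read by MTT assay, with a stated time of 72 h; a higher number here means a weaker inhibitor, a lower number a stronger inhibitor:
- compound 1 `O=c1cc(CSC(=S)N2CCCC2)oc2ccccc12`; compound 1 gives 40000 nM
- compound 2 `O=c1cc(CSC(=S)N2CCCCC2)oc2ccccc12`; compound 2 gives only a limit of the assay, > 25000 nM

Compound 2 therefore stands on a limit in this assay, not on a number. Going by the values given here, the one measured step, a step that the limit leaves unreadable from compound 1 to compound 2, cannot be read in size or direction because the limit of > 25000 nM in this assay, at which 1 of the 2 values shown sits, hides where compound 2 actually sits. Among the compounds with values here, compound 1 gives the only numerical value, and it marks weak inhibition.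

Compound 3 `COc1ccc2oc(CSC(=S)N3CCCCC3)cc(=O)c2c1` differs from compound 2 by methoxy in place of hydrogen on an aromatic carbon of a six-membered aromatic ring of carbon only, part of a fused or bridged system of two rings; meta to a fused ring; para to a fused ring. Within the data shown here, no measured step touches this ring or a methoxy group, and the single step that exists is unreadable, so the measured data give no direction for this change. The expectation for compound 3 can only be anchored on compound 1 and on the limit of compound 2, both of which mark weak activity. Compound 3 is expected to show a step that the limit leaves unreadable from compound 2 to compound 3 in this assay, in effect no shift beyond the scatter, with a fair chance of again reporting only a limit. Compound 3 is estimated at 35000 nM, within 9000 nM to 120000 nM.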

Compound 3, half-maximal inhibitory concentration: 5000 nM
For compound 3 the middle estimate is 7.0-fold (0.85 log units) above the measured one, and the stated range ends above it.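

In this assay, going by these compounds alone, methoxy in place of hydrogen on an aromatic carbon gives an at least 5.0-fold lower number from compound 2 to compound 3 (0.69 log units; beyond the scatter), the first step that can be read and the first to lie beyond the scatter. The earlier pair changed only the ring on the thiocarbonyl carbon, and its step cannot be read; this result shows that the aromatic ring of the shared core, at the carbon meta to a fused ring and para to a fused ring, is a place where a single change moves the number. The printed step is only a minimum, because compound 2 stands on a limit and not on a number: the limit of > 25000 nM in this assay, at which 1 of the 3 values shown sits.

Still open, on these data alone, is whether this shift is particular to methoxy, or whether a hydroxyl group, a chlorine atom or the longer ethoxy chain on the same carbon would move the number in the same way. Also open, as far as these compounds go, is whether methoxy would give a comparable step on the pyrrolidin-1-yl partner, compound 1, since a single step on the piperidin-1-yl compounds sets no pattern for the series.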